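The source may report more compounds than this note shows. Statements on the series, on what has been measured and on what is new or still open speak of the compounds shown alone.

Measured compounds:
compound 1 `CCCCCCOC(=O)c1cccc(-c2cc(C(=O)Nc3ccncc3)ccc2CN)c1` — 22 nM
compound 2 `NCc1ccc(C(=O)Nc2ccncc2F)cc1-c1cccc(C(=O)OCCO)c1` — 1.4 nM
compound 3 `NCc1ccc(C(=O)Nc2ccncc2F)cc1-c1cccc(C(=O)OCC2CCCCO2)c1` — 12 nM

In an assay on isolated protein for inhibition of Rho-associated protein kinase 2 (Homo sapiens), read by radiometric assay (on this read-out higher numbers stand for weaker inhibition and lower numbers for stronger inhibition), compound 1 gives the highest number of the three. Against compound 3 the gap is within the scatter; against compound 2 it is well beyond it. Among the measured compounds shown here, the one single-site step within the set is on the ester chain: an 8.6-fold higher number from compound 2 to compound 3 (0.93 log units; beyond the scatter).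

Compound 4 `COC(=O)c1cccc(-c2cc(C(=O)Nc3ccncc3)ccc2CN)c1` differs from compound 1 only at the ester: hydrogen in place of pentyl on a saturated chain carbon bound to an oxygen next to a carbonyl group, that is hexyloxycarbonyl to methoxycarbonyl. For the measured compounds named here, no measured pair covers this exact change. The step from compound 2 to compound 3 shows that the group on the ester chain can shift this assay by a modest amount, with the larger group giving the higher number. Compound 1 carries the longest chain of the set, and compound 2 with the smallest ester terminus gives the lowest number, though compound 2 and compound 3 also carry a fluorine that compound 1 lacks, so that comparison is not clean. Cutting the chain back to methyl is therefore expected to give a modest step downward, a 1.8-fold lower number from compound 1 to compound 4 (0.26 log units; within the scatter). For compound 4 the expected value in this assay is 12 nM, with a range of 4 nM to 40 nM.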

Compound 4, half-maximal inhibitory concentration: 2.9 nM
For compound 4 the middle estimate is 4.1-fold (0.62 log units) above the measured one, outside the stated range (below it).
By their numbers in this assay, from the lowest: compound 2; then compound 4; then compounds 3 and 1 (each within the scatter of the next).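

In this assay, cutting hexyloxycarbonyl back to methoxycarbonyl moves the number beyond the scatter (a 7.6-fold lower number from compound 1 to compound 4 (0.88 log units; beyond the scatter)), so the ester chain matters on the core of compound 1 too, and not only on the fluorine-bearing core of compound 2 (an 8.6-fold higher number from compound 2 to compound 3 (0.93 log units; beyond the scatter)). In both of these pairs, the larger group on the saturated chain carbon bound to an oxygen next to a carbonyl group gives the higher number, and neither pair goes against this, though two pairs are a thin basis for a pattern. Nothing measured here accounts for the step.

On these data alone, whether an ethyl or butyl chain would fall between compound 4 and compound 1 stays open, as does the outcome with a carboxylic acid in place of the ester. Among the compounds shown here, no pair isolates the fluorine carried by compound 2 and compound 3.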